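Aryl sulfonamide change in a 5-hydroxytryptamine receptor 4 series

A few compounds are considered here, and "the series" means these few. Any claim that something is new, unique, unknown or untested is made for them only; others in the source may bear on it.

Compound 1 `COc1cc(N)c(Cl)cc1C(=O)CCC1CCN(CCNS(=O)(=O)c2ccc(C)cc2)CC1` gives 18 nM in an assay on brain for displacement of a labelled ligand from 5-hydroxytryptamine receptor 4 (Cavia porcellus), with a stated time of 30 min, in the presence of a further agent that is not named here; on this read-out lower numbers stand for stronger inhibition and higher numbers for weaker inhibition. Compound 2 `COc1ccc(S(=O)(=O)NCCCN2CCC(CCC(=O)c3cc(Cl)c(N)cc3OC)CC2)cc1` gives 26 nM in this assay. Of these two numbers, that of compound 1 is the smaller, but the gap falls within the usual scatter, so the two stand together rather than apart.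

Compound 3 `COc1cc(N)c(Cl)cc1C(=O)CCC1CCN(CCNS(=O)(=O)c2cc(Br)c(N)c(Br)c2)CC1` is not yet measured. It differs from compound 1 in one place: 4-amino-3,5-dibromophenyl in place of 4-methylphenyl on a sulfonyl sulfur. For the measured compounds named here, no measured pair shows a change of this kind; compound 1 and compound 2 differ in both the aryl sulfonamide and the chain at once, and their values stay within the scatter. The step expected in this assay is a 1.1-fold higher number from compound 1 to compound 3 (0.05 log units; within the scatter), none beyond the scatter and with no direction preferred. For compound 3 the estimate is 20 nM, with a range from 6 nM to 70 nM.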

Compound 3, inhibition constant: 8.7 nM
Compound 3: the middle estimate sits 2.3-fold (0.36 log units) above what was measured; the measured number falls inside the stated range.
By their numbers in this assay, from the lowest: compound 3; then compounds 1 and 2 (each within the scatter of the next).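

In this assay, exchanging 4-methylphenyl for 4-amino-3,5-dibromophenyl on the sulfonyl sulfur, with the rest of compound 1 unchanged, gives a modest step beyond the scatter (a 2.1-fold lower number from compound 1 to compound 3 (0.32 log units; beyond the scatter)). For the compounds shown here, this is the first reading of this position alone, since compound 1 and compound 2 differ in both the aryl sulfonamide and the chain; here, the larger aryl group, which brings a hydrogen-bond donor and acceptor, is accepted without loss of binding. Nothing measured here accounts for the step.

The change adds the amine and both bromines at once, so their shares in the step remain unresolved; a 4-aminophenyl group without the bromines and a 3,5-dibromophenyl group without the amine would separate them. On these data alone, whether the same step holds on the chain of compound 2 also remains open.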